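Replacing a ring-bearing side chain with hexyloxy

The compounds below may be only part of what the source reports. "The series", "measured", "known", "first", "only" and "open" are said of these compounds alone.

In a physicochemical assay for solubility, in phosphate buffer, with a stated time of 18 h, at pH 7.4 (a higher number here means a more soluble compound, a lower number a less soluble compound), compound 1 (`COc1cc2ncnc(-n3nc(-c4ccccc4)nc3N)c2cc1OC`) gives 1000 nM and compound 2 (`COc1cc2ncnc(-n3nc(-c4ccccn4)nc3N)c2cc1OCCCNC(=O)CN1C[C@@H](C)O[C@@H](C)C1`) gives 34000 nM as the higher of the two numbers, a gap well beyond the scatter. Compound 3 (`CCCCCCOC(=O)NCCCOc1cc2c(-n3nc(-c4ccccn4)nc3N)ncnc2cc1OC`) has not yet been measured. It carries hexyloxy in place of (2,6-dimethylmorpholin-4-yl)methyl on a carbonyl carbon so the six-membered ring of compound 2 is gone. For the measured compounds named here, no measured pair of compounds isolates this change, which leaves any forecast uncertain. The nearest guide is compound 1, which also lacks that ring and gives 1000 nM while differing from compound 3 in other places too. A large fall, beyond the scatter, is expected, and the estimated change is a 34-fold lower number from compound 2 to compound 3 (1.53 log units; beyond the scatter) in this measurement. For compound 3 the estimated value is 1000 nM with an expected range from 150 nM to 6000 nM in this assay as the read-out.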

Compound 3, solubility: 1000 nM
Compound 3: the middle estimate sits on the measured number at the digits printed; measured number inside the range.
By their numbers in this assay, from the lowest: compounds 1 and 3 (each within the scatter of the next); then compound 2.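

Putting hexyloxy in place of (2,6-dimethylmorpholin-4-yl)methyl on a carbonyl carbon gives a 34-fold lower number from compound 2 to compound 3 (1.53 log units; beyond the scatter) in this assay. This is the first pair shown that differs in one place only, so it shows that the group on this carbonyl carbon can by itself move the number by a large step, with the rest of the molecule unchanged. No measurement shown gives a reason for the step, so it records what happens and not why.

This single step does not separate the loss of the ring from the other differences between the two groups. A morpholin-4-ylmethyl group without the two methyl groups, an open-chain dimethylaminomethyl group or a shorter butyloxy chain on the same carbonyl carbon could each help show which part of the change goes with the step.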